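The source may hold more compounds than are shown below. What is called first, only, known or untested is meant among the compounds shown, and "the series" means these compounds.

Measured so far in an in vitro assay on HEK-tsA201 cells for antagonist activity at Neuronal acetylcholine receptor; alpha4/beta2 (Homo sapiens), read by fluorescence and calcium flux; on this read-out lower numbers stand for stronger inhibition and higher numbers for weaker inhibition:
compound 1 `C=CCOc1ccc(C(=O)Nc2cccc(C)n2)cc1` gives 6000 nM.
compound 2 `C=CCOc1ccc(C(=O)Nc2cccc(Cl)n2)cc1` gives > 100000 nM, which is a limit of the assay, not a number.

Compound 2 therefore stands only at the limit of > 100000 nM in this assay, at which 1 of the 2 values shown sits. Compound 3 `C=CCOc1ccc(C(=O)Nc2cccc(CC)n2)cc1` differs from compound 2 by ethyl in place of chloro on an aromatic carbon. For the measured compounds named here, the only measured step at this position is an at least 16-fold higher number from compound 1 to compound 2 (1.22 log units; beyond the scatter), a large loss on going from methyl to chloro. Since ethyl, like methyl, is a hydrocarbon group, a return toward the number of compound 1 is expected, estimated as an at least 12-fold lower number from compound 2 to compound 3 (1.09 log units; beyond the scatter) in this assay. The expected value for compound 3 is 8000 nM, ranging from 2000 nM to 50000 nM.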

Compound 3, half-maximal inhibitory concentration: 20500 nM
Estimate against measurement, compound 3: 2.6-fold (0.41 log units) below, within the range that was stated.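

Ethyl gives an at least 4.8-fold lower number from compound 2 to compound 3 (0.68 log units; beyond the scatter) and so takes back part of the loss seen with chloro at this position. Measured against methyl, ethyl still gives a 3.4-fold higher number from compound 1 to compound 3 (0.53 log units; beyond the scatter) and so the position separates even these two hydrocarbon groups. The first of these steps is only a bound, since compound 2 sits at a limit of the assay and not at a number: the limit of > 100000 nM in this assay, at which 1 of the 3 values shown sits.

Still open, going by these compounds, is whether the loss from methyl to ethyl continues along a longer chain such as propyl. Also open, on these data alone, is how an amine or a methoxy group at this position compares with methyl.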